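Trimming the Amide Tail: Ethyl to Methyl

The compounds below may be only part of what the source reports. "The series", "measured", "known", "first", "only" and "open" are said of these compounds alone.

Compound 2 `CCNC(=O)C1=Cc2ccc(OC)cc2OC1c1cc(OC)c(OC)c(OC)c1` carries an ethylamino group on its carbonyl carbon. In a functional assay for inhibition of nuclear factor NF-kappa-B complex (Homo sapiens) (on this read-out higher numbers stand for weaker inhibition and lower numbers for stronger inhibition), compound 2 gives only a limit, > 50000 nM. Compound 1 `COc1ccc2c(c1)OC(c1cc(OC)c(OC)c(OC)c1)C(C(=O)OCCc1ccccc1)=C2` is the phenethyloxy counterpart; in this assay compound 1 gives 16200 nM, and the step of an at least 3.0-fold higher number from compound 1 to compound 2 (0.48 log units; beyond the scatter) is the only measured one. Compound 3 `CNC(=O)C1=Cc2ccc(OC)cc2OC1c1cc(OC)c(OC)c(OC)c1` differs from compound 2 by hydrogen in place of methyl on a saturated chain carbon bound to an amide-type nitrogen. Among the compounds with values here, no measured step covers such a small change, so no shift beyond the scatter is expected, and compound 2 already sits at the limit (the limit of > 50000 nM in this assay, at which 1 of the 2 values shown sits). Compound 3 is therefore expected to give about 60000 nM, within 20000 nM to 200000 nM, a step that the limit leaves unreadable from compound 2 to compound 3.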

Compound 3, half-maximal inhibitory concentration: > 50000 nM
Compound 3 ended at the assay's limit (the forecaster's own chance of this, stated with the estimate: 75%); the middle value is on the limit's open side.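

In this assay compound 3 also gives only a limit, > 50000 nM, so the step from the ethylamino to the methylamino amide cannot be read. Methylamino in place of phenethyloxy on the carbonyl carbon gives an at least 3.0-fold higher number from compound 1 to compound 3 (0.48 log units; beyond the scatter), the same direction as seen with ethylamino. Trimming the amide tail therefore brings back no readable value, and the values now gather at the end of the assay's range: the limit of > 50000 nM in this assay, at which 2 of the 3 values shown sit.

Still open, on these data alone, is whether phenethylamino, which keeps the tail of compound 1 on an amide, would give a readable value. A plain methoxy group on the carbonyl carbon would show how much the ester depends on its phenethyl tail.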